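The source may report more compounds than this note shows. Statements on the series, on what has been measured and on what is new or still open speak of the compounds shown alone.

Three compounds of the series have numbers in an ADME assay on MT4 cells (Homo sapiens) for cytotoxicity, read by MTT assay, with a stated time of 4 days; a higher number here means that more compound is tolerated, a lower number that less compound is tolerated. Compound 1, `N#Cc1ccc(Nc2nc(N)nc(Oc3ccc(Cl)c4ccccc34)n2)cc1`, gives 237000 nM. Compound 2, `CCCNc1nc(Nc2ccc(C#N)cc2)nc(Oc2ccc(Cl)c3ccccc23)n1`, gives 182000 nM. Compound 3, `N#Cc1ccc(Nc2nc(N)nc(Oc3ccc4ccccc4c3Br)n2)cc1`, gives 133000 nM. The difference between the core of compound 1 and the core of compound 3 is not broken down here; their two numbers lie within the usual scatter of each other.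

Compound 1 and compound 2 are linked by one change, (propyl in place of hydrogen on a nitrogen on an aromatic ring), and that change made a step of a 1.3-fold lower number from compound 1 to compound 2 (0.11 log units; within the scatter) in this assay.

Compound 4, `CCCNc1nc(Nc2ccc(C#N)cc2)nc(Oc2ccc3ccccc3c2Br)n1`, is not yet measured. It carries the same change relative to compound 3: propyl in place of hydrogen on a nitrogen on an aromatic ring. The place of the change is described in the same words for both pairs, so this is the same change, seen twice among the four compounds. Nothing else separates compound 3 from compound 4, and nothing else separated compound 1 from compound 2.

The expected step from compound 3 to compound 4 in this assay is a 1.3-fold lower number from compound 3 to compound 4 (0.10 log units; within the scatter), expected to resemble the step already seen because a 1.3-fold lower number from compound 1 to compound 2 (0.11 log units; within the scatter) stayed within the scatter when the same propyl for hydrogen change was made on compound 1. On that basis compound 4 is estimated at 105000 nM, with a likely range from 55000 nM to 200000 nM.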

Compound 4, half-maximal cytotoxic concentration: > 263000 nM
Compound 4: a limit, no number; the forecaster's own chance of this, stated with the estimate: 10%; middle value at least 2.5-fold (0.39 log units) away from the limit.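

In this assay compound 4 gives > 263000 nM, which is a limit of the assay and not a number. With propyl in place of hydrogen on the nitrogen, the new step reads an at least 1.9-fold higher number from compound 3 to compound 4 (0.29 log units; that floor lies within the scatter), and its size cannot be set firmly against the earlier step on the other core: the same change on two cores in this assay, a 1.3-fold lower number (0.11 log units; within the scatter) from compound 1 to compound 2 and an at least 1.9-fold higher number (0.29 log units; that floor lies within the scatter) from compound 3 to compound 4; the limit leaves it open whether they differ

Going by these compounds alone, on these two pairs, the change gives no lower number beyond the scatter on either core, but that is as far as the reading goes: it does not show that the size or direction of the step carries from one core to the other, and with only two pairs it supports no rule for the series.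

Open questions remain about how far the number for the propylamino compound on the core of compound 3 lies from the limit, and whether a number rather than a limit would separate the two steps. Also open, on these data alone, is how this nitrogen behaves with other groups in place of propyl, such as a longer chain like butyl, a cyclic amine or a chain ending in a carboxylic acid, on either core.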